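The source may report more compounds than this note shows. Statements on the series, on what has been measured and on what is new or still open speak of the compounds shown alone.

In a functional assay on A549 cells (Homo sapiens) for antiproliferative activity, read by MTT assay, with a stated time of 72 h (a higher number here means a weaker inhibitor, a lower number a stronger inhibitor), compound 3 `CCN(CC)CCn1cccc1/C=N/NC(=O)Nc1ccc(Oc2ccnc3[nH]ccc23)cc1` gives 3570 nM, level with compound 2 `O=C(N/N=C/c1cccc([N+](=O)[O-])c1)Nc1ccc(Oc2ccnc3[nH]ccc23)c(F)c1` at 3640 nM, while the number for compound 1 `O=C(N/N=C/c1ccc(F)cc1)Nc1ccc(Oc2ccnc3[nH]ccc23)c(F)c1`, 680 nM, is clearly lower. Compound 4 `O=C(N/N=C/c1cccn1CCCN1CCCCC1)Nc1ccc(Oc2ccnc3[nH]ccc23)cc1` differs from compound 3 by (piperidin-1-yl)methyl in place of diethylamino on a saturated chain carbon, two bonds along the chain from an aromatic nitrogen, which turns 2-(diethylamino)ethyl into 3-(piperidin-1-yl)propyl. For the measured compounds named here, the only measured step, a 5.4-fold higher number from compound 1 to compound 2 (0.73 log units; beyond the scatter), is modest and lies at another place, 3-nitrophenyl in place of 4-fluorophenyl, so it shows only that this series can move beyond the scatter. Going by the values given here, no measured step touches the chain, and no change beyond the scatter is expected in this assay. The expected step is a 1.3-fold lower number from compound 3 to compound 4 (0.11 log units; within the scatter). Compound 4 is estimated at 2800 nM, with an expected range from 1000 nM to 7000 nM.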

Compound 4, half-maximal inhibitory concentration: 1560 nM
Estimate against measurement, compound 4: 1.8-fold (0.25 log units) above; measured number inside the range.
By their numbers in this assay, from the lowest: compound 1; then compound 4; then compounds 3 and 2 (each within the scatter of the next).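

The chain is not silent in this assay: 3-(piperidin-1-yl)propyl in place of 2-(diethylamino)ethyl gives a 2.3-fold lower number from compound 3 to compound 4 (0.36 log units; beyond the scatter). For the compounds shown here, this is the first measured step at this position, and it lies beyond the scatter, though it is modest. No available data give a reason for this shift. The change alters the chain and the amine together, so the compounds shown cannot separate the two. A 3-(diethylamino)propyl or 2-(piperidin-1-yl)ethyl chain would tell them apart.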